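Swapping the aryl group on the piperazine of a hydantoin

The source may report more compounds than this note shows. Statements on the series, on what has been measured and on what is new or still open speak of the compounds shown alone.

Measured so far:
compound 1 `CC(C)C1(C(C)C)NC(=O)N(CN2CCN(C)CC2)C1=O` — 300 mg/kg
compound 2 `CC(C)C1(C(C)C)NC(=O)N(CN2CCN(c3cccc(Cl)c3)CC2)C1=O` — 100 mg/kg
compound 3 `O=C1NC(c2ccccc2)(c2ccccc2)C(=O)N1CN1CCN(Cc2ccccc2)CC1` — 300 mg/kg

In a functional assay on the whole organism (strain CD1) with Mus musculus as the target, in the maximal electroshock model, with a stated time of 0.5 h (on this read-out higher numbers stand for an effect only at larger amounts of compound and lower numbers for an effect already at smaller amounts), compound 2 gives 100 mg/kg, the lowest number among the three measured compounds. Compound 1 gives 300 mg/kg and compound 3 gives 300 mg/kg, both separated from compound 2 by the same margin and both beyond the scatter. Going by the values given here, the one step that is directly defined, a 3.0-fold lower number from compound 1 to compound 2 (0.48 log units; beyond the scatter), replaces a small group on the piperazine nitrogen with an aryl ring and lowers the number modestly.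

Compound 4 `CC(C)C1(C(C)C)NC(=O)N(CN2CCN(c3ccccc3F)CC2)C1=O` keeps an aryl ring on that nitrogen and changes only its substitution: 2-fluorophenyl in place of 3-chlorophenyl on an amine nitrogen in a ring. Among the compounds with values here, no measured pair compares one aryl ring with another here, so there is no basis for expecting a move beyond the scatter. The step of a 1.5-fold higher number from compound 2 to compound 4 (0.18 log units; within the scatter) is therefore estimated to be small, in either direction. Compound 4 is expected to give 150 mg/kg in this assay, with a range from 75 mg/kg to 300 mg/kg.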

Compound 4, minimum effective dose: 100 mg/kg
Compound 4: the middle estimate sits 1.5-fold (0.18 log units) above what was measured; the measured number falls inside the stated range.
By their numbers in this assay, from the lowest: compounds 2 and 4 (each within the scatter of the next); then compounds 1 and 3 (each within the scatter of the next).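

In this assay, going by these compounds alone, the first comparison of one aryl ring with another on this amine nitrogen shows no change at the digits printed from compound 2 to compound 4 (within the scatter), so 3-chlorophenyl and 2-fluorophenyl cannot be told apart at this position. The exchange of methyl for an aryl ring now has a second example, a 3.0-fold lower number from compound 1 to compound 4 (0.48 log units; beyond the scatter), which matches a 3.0-fold lower number from compound 1 to compound 2 (0.48 log units; beyond the scatter) in size. The lower number therefore does not belong to 3-chlorophenyl alone but also appears with 2-fluorophenyl, although these two groups differ in both the halogen and where it sits on the ring.

Going by these compounds, it remains open whether an unsubstituted phenyl, a pyridine ring or a 4-methoxyphenyl on the same nitrogen would give a number like those of compound 2 and compound 4. The data shown offer no explanation for the shared result.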